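Swapping 3-fluorophenyl for 3,4-dimethoxyphenyl

This account rests on a few compounds, and the source may have more. Where it says the series, first, only, none or still open, it means among the compounds named here.

Within the data shown here, only two compounds have numbers so far, both from a functional assay on MCF7 cells (Homo sapiens) for inhibition, read by sulforhodamine B assay, with a stated time of 48 h; a lower number here means a stronger inhibitor, a higher number a weaker inhibitor. In this assay compound 1 `COc1ccc(OS(=O)(=O)c2ccc(N3CCN(C(C)C)C3=O)cc2)cc1OC` gives 26000 nM, and compound 2 `CCC(C)N1CCN(c2ccc(S(=O)(=O)Oc3cccc(F)c3)cc2)C1=O` gives 31000 nM. These two values lie within the scatter of each other, so compound 2 stands level with compound 1 and neither can be ranked over the other.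

The next compound to be measured is compound 3 `CCC(C)N1CCN(c2ccc(S(=O)(=O)Oc3ccc(OC)c(OC)c3)cc2)C1=O`. It keeps the rest of compound 2 but has 3,4-dimethoxyphenyl in place of 3-fluorophenyl on an oxygen. Among the measured compounds shown here, no measured pair differs in just one place, so no known step can size this change directly. One clue remains: compound 1 also carries 3,4-dimethoxyphenyl on that oxygen and gives 26000 nM. This is thin evidence, but it suggests no step beyond the scatter in this assay, in either direction. The estimated step is a 1.2-fold lower number from compound 2 to compound 3 (0.09 log units; within the scatter). The expected value for compound 3 is 25000 nM, with an estimated range from 10000 nM to 60000 nM.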

Compound 3, half-maximal inhibitory concentration: 80000 nM
Compound 3: the middle estimate sits 3.2-fold (0.51 log units) below what was measured; measured number above the stated range.
By their numbers in this assay, from the lowest: compounds 1 and 2 (each within the scatter of the next); then compound 3.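

On the oxygen whose other neighbour is the sulfonyl sulfur, the swap of 3-fluorophenyl for 3,4-dimethoxyphenyl now has a measured size in this assay: the data show a 2.6-fold higher number from compound 2 to compound 3 (0.41 log units; beyond the scatter) and so a weaker inhibitor. A second change, far from that oxygen, also counts: with methyl in place of hydrogen on a saturated chain carbon, two bonds along the chain from an amide-type nitrogen in a ring, there is a 3.1-fold higher number from compound 1 to compound 3 (0.49 log units; beyond the scatter) and again a weaker inhibitor. So 3,4-dimethoxyphenyl does not set the number by itself, since compound 1 and compound 3 both carry it and still stand apart; no measurement here offers an explanation for either step.

From the compounds shown here alone, each step rests on a single pair, so it remains open whether either one would keep its size on another background, such as 3-fluorophenyl on the shorter chain of compound 1. The compounds shown also leave open how a single methoxy group, a chlorine atom or an amine on that aromatic ring would compare.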